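Compound 3: 2-methylphenyl in place of cyclopropyl

The source may hold more compounds than are shown below. What is called first, only, known or untested is meant among the compounds shown, and "the series" means these compounds.

Measured in a physicochemical assay for lipophilicity, read by HPLC, at pH 7.4; on this read-out lower numbers stand for lower lipophilicity and higher numbers for higher lipophilicity
- compound 1 `Cc1ccccc1N1C(=O)/C(=C/c2ccc(O)c(Cl)c2)S/C1=N\CCO` gives 1.9
- compound 2 `CCC/N=C1\S/C(=C\c2ccc(O)c(Cl)c2)C(=O)N1C1CC1` gives 3.4

Compound 2 stands highest of the two numbers, and compound 1 lies lower by a gap beyond the scatter. Compound 3 `CCC/N=C1\S/C(=C\c2ccc(O)c(Cl)c2)C(=O)N1c1ccccc1C` differs from compound 2 by 2-methylphenyl in place of cyclopropyl on an amide-type nitrogen in a ring. Among the compounds with values here, no measured step isolates this change, so the expectation remains tentative: an upward move beyond the scatter. The expected size is a number 0.70 log units higher from compound 2 to compound 3 (beyond the scatter) (an estimate). The estimated value for compound 3 is 4.1 (range 3.6 to 4.7).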

Compound 3, distribution coefficient: 3.8
Estimate against measurement, compound 3: 0.30 log units above; low and high end bracket the measured number.
By their numbers in this assay, from the lowest: compound 1; then compound 2; then compound 3.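

In this assay, the position on the amide-type nitrogen in a ring now has a measured step: 2-methylphenyl in place of cyclopropyl gives a number 0.40 log units higher from compound 2 to compound 3 (beyond the scatter) with the propyl-bearing side unchanged. With 2-methylphenyl held constant, methyl in place of hydroxy on the saturated chain carbon, two bonds along the chain from a double-bonded nitrogen, gives a number 1.90 log units higher from compound 1 to compound 3 (beyond the scatter) as the second single-place comparison in the series. No evidence at hand accounts for either step.

Each change rests on a single pair, so neither step is known to hold on other compounds of the series. As far as these compounds go, how a longer chain on the amide-type nitrogen, or an amine or a carboxylic acid at the end of the chain, would stand in this assay remains open.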